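Removing the Fluoro Group from Compound 3

A few compounds are considered here, and "the series" means these few. Any claim that something is new, unique, unknown or untested is made for them only; others in the source may bear on it.

Measured in a functional assay on SW480 cells (Homo sapiens) for antiproliferative activity, read by MTT assay, with a stated time of 48 h; a lower number here means a stronger inhibitor, a higher number a weaker inhibitor:
compound 1 `CCCC(CCO)n1cnc2c(Cl)ncnc21`: > 50000 nM (a limit)
compound 2 `CCCCC(CCO)n1cnc2c(Cl)ncnc21`: > 50000 nM (a limit)
compound 3 `CCCCCC(CCO)n1cnc2c(Cl)nc(F)nc21`: 7440 nM

Compound 3 is the only one of these with a true number. Compound 1 and compound 2 both stop at a limit: the limit of > 50000 nM in this assay, at which 2 of the 3 values shown sit. Compound 4 `CCCCCC(CCO)n1cnc2c(Cl)ncnc21` differs from compound 3 in one place: hydrogen in place of fluoro on an aromatic carbon. Among the measured compounds shown here, the only measured step, a step that the two limits leave unreadable from compound 1 to compound 2, lies in the chain and not at this carbon, and its size cannot be read. Compound 2, which also has hydrogen on that carbon but a shorter chain, sits at the limit > 50000 nM, so a weaker result is expected. The expected change is a 2.7-fold higher number from compound 3 to compound 4 (0.43 log units; beyond the scatter). For compound 4 the estimate is 20000 nM, with an expected range of 6000 nM to 60000 nM.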

Compound 4, half-maximal inhibitory concentration: > 50000 nM
Compound 4: only a limit was reported; the forecaster's own chance of this, stated with the estimate: 35%; middle value at least 2.5-fold (0.39 log units) from the limit.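

In this assay, the fluoro group on the aromatic carbon between two ring nitrogen atoms now has a readable effect: replacing it with hydrogen gives an at least 6.7-fold higher number from compound 3 to compound 4 (0.82 log units; beyond the scatter). Compound 4 ends at a limit, not a number: the limit of > 50000 nM in this assay, at which 3 of the 4 values shown sit. Compound 1 and compound 2 also carry hydrogen on this carbon, so they could not show this effect, and the steps among compound 1, compound 2 and compound 4 cannot be read.

Going by these compounds, the full size of the step stays open. So does what an amine or a methoxy group on this carbon would do, and whether the step holds with a longer chain.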